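This account rests on a few compounds, and the source may have more. Where it says the series, first, only, none or still open, it means among the compounds named here.

Measured so far in a functional assay on ACHN cells (Homo sapiens) for antiproliferative activity, read by XTT assay; a lower number here means a stronger inhibitor, a higher number a weaker inhibitor:
compound 1 `O=c1c(Cc2coc3ccccc3c2=O)coc2ccccc12`, giving 510 nM
compound 2 `O=c1c(Cc2coc3cccc(O)c3c2=O)coc2ccccc12`, giving 740 nM

Compound 2 stands with compound 1 inside the usual scatter: the step of a 1.5-fold higher number from compound 1 to compound 2 (0.16 log units; within the scatter) does not separate them. Compound 3 `COc1cccc2occ(Cc3coc4ccccc4c3=O)c(=O)c12` differs from compound 2 by methyl in place of hydrogen on an oxygen on an aromatic ring. Within the data shown here, no measured step touches a methyl on an oxygen; the only step available, hydrogen to hydroxy on an aromatic carbon, moved nothing beyond the scatter. Capping that hydroxy is therefore expected to leave this assay about unchanged, with a step of a 1.1-fold lower number from compound 2 to compound 3 (0.06 log units; within the scatter) expected. Compound 3 is estimated at 650 nM, within 250 nM to 1800 nM.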

Compound 3, half-maximal inhibitory concentration: 340 nM
Beside the measured number, compound 3's estimate is 1.9-fold (0.28 log units) above it, within the range that was stated.
By their numbers in this assay, from the lowest: compounds 3, 1 and 2 (each within the scatter of the next, the first and the last beyond it).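

Methyl in place of hydrogen on the oxygen on the aromatic ring gives the first step at this position that lies beyond the scatter in this assay (a 2.2-fold lower number from compound 2 to compound 3 (0.34 log units; beyond the scatter)). The step is modest, and methoxy in place of hydrogen on the aromatic carbon stays within the scatter (a 1.5-fold lower number from compound 1 to compound 3 (0.18 log units; within the scatter)), so the position shows only a small separation between hydroxy and methoxy. No available evidence bears on the origin of this step.

On these data alone, whether a longer chain on that oxygen, such as ethoxy, or an amine on the same aromatic carbon would move the number further remains open. Whether the methyl step holds elsewhere on the shared core is also unresolved.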